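Trimming one methyl from the unsaturated amide tail

This account rests on a few compounds, and the source may have more. Where it says the series, first, only, none or still open, it means among the compounds named here.

Compound 1 `C=CC(=O)Nc1cc2c(N3CCc4ccccc43)ncnc2cc1O[C@@H]1CCOC1` gives 2710 nM in a functional assay on PC-3 cells (Homo sapiens) for antiproliferative activity, read by MTT assay, with a stated time of 72 h; on this read-out higher numbers stand for weaker inhibition and lower numbers for stronger inhibition.
Compound 2 `C=C(C)C(=O)Nc1cc2c(N3CCc4ccccc43)ncnc2cc1O[C@@H]1CCOC1` gives 4910 nM in this assay.
Compound 3 `CC(C)=CC(=O)Nc1cc2c(N3CCc4ccccc43)ncnc2cc1O[C@@H]1CCOC1` gives 4620 nM in this assay.

All three share one core and differ only in the unsaturated acyl group on the amide nitrogen. Among these three numbers compound 3 sits second highest, yet every gap is small: there is a 1.1-fold lower number from compound 2 to compound 3 (0.03 log units; within the scatter) and a 1.7-fold higher number from compound 1 to compound 3 (0.23 log units; within the scatter), so the three compounds cannot be ranked with any confidence.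

Compound 4 `C/C=C/C(=O)Nc1cc2c(N3CCc4ccccc43)ncnc2cc1O[C@@H]1CCOC1` continues this series with the change (prop-1-en-1-yl in place of 2-methylprop-1-en-1-yl on a carbonyl carbon). Of the measured steps, the most relevant are a 1.7-fold higher number from compound 1 to compound 3 (0.23 log units; within the scatter) and a 1.1-fold lower number from compound 2 to compound 3 (0.03 log units; within the scatter), both of which alter the same chain by adding or moving a methyl, and neither moved the number beyond the scatter. Removing one methyl from compound 3 to give compound 4 is the reverse of such a move, so no step beyond the scatter is expected in this assay, with at most a slight drift toward the lower number seen for compound 1, whose value is 2710 nM.

Compound 4 is therefore estimated at 3600 nM, within a range of 1600 nM to 8000 nM, meaning an expected step of a 1.3-fold lower number from compound 3 to compound 4 (0.11 log units; within the scatter).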

Compound 4, half-maximal inhibitory concentration: 5220 nM
Estimate against measurement, compound 4: 1.5-fold (0.16 log units) below; the measured number falls inside the stated range.
By their numbers in this assay, from the lowest: compounds 1, 3, 2 and 4 (each within the scatter of the next).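

In this assay, prop-1-en-1-yl in place of 2-methylprop-1-en-1-yl on a carbonyl carbon gives a 1.1-fold higher number from compound 3 to compound 4 (0.05 log units; within the scatter), so taking one methyl off this chain does not separate the two compounds. The comparisons with the other two acyl groups read the same way, with a 1.1-fold higher number from compound 2 to compound 4 (0.03 log units; within the scatter) and a 1.9-fold higher number from compound 1 to compound 4 (0.28 log units; within the scatter), which means that vinyl, 1-methylethenyl, 2-methylprop-1-en-1-yl and prop-1-en-1-yl all lie within the scatter of one another at this position, and the fourth chain adds no separation that the first three lacked. Nothing available on these compounds offers an explanation for how closely their numbers agree.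

All four groups shown are short hydrocarbon chains that keep one double bond, so it remains open whether a chain carrying an amine, such as a dimethylaminomethyl group on the end of the prop-1-en-1-yl chain, would give a step beyond the scatter. On these data alone, it also remains open whether a saturated propyl chain on the same carbonyl carbon, with no double bond outside the aromatic rings, would stay within the scatter of these four compounds.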